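The compounds below may be only part of what the source reports. "The series", "measured", "known", "first", "only" and "open" are said of these compounds alone.

Compound 1, `CCCCCCC(Sc1nc(Cl)cc(Nc2nc(-c3ccc(C)cc3)cs2)n1)C(=O)O`: 200 nM
Compound 2, `CCCCCCC(Sc1nc(Cl)cc(Nc2nc(-c3ccc(F)cc3F)cs2)n1)C(=O)O`: 1500 nM
Compound 3, `CCCCCCC(Sc1nc(Cl)cc(Nc2nc(-c3ccc(-c4ccccc4)cc3)cs2)n1)C(=O)O`: 300 nM

In an assay for inhibition of Polyunsaturated fatty acid 5-lipoxygenase (Homo sapiens), read by HPLC, with stated times of 15 min and 10 min (a lower number here means a stronger inhibitor, a higher number a weaker inhibitor), compound 3 stands second highest of the three numbers. Its nearest neighbour is compound 1, separated by a 1.5-fold higher number from compound 1 to compound 3 (0.18 log units; within the scatter), a gap within the scatter. Its furthest is compound 2, separated by a 5.0-fold lower number from compound 2 to compound 3 (0.70 log units; beyond the scatter).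

Compound 4, `CCCCCCC(Sc1nc(Cl)cc(Nc2nc(-c3ccc(OC)cc3)cs2)n1)C(=O)O`, has not yet been measured in this assay. The change from compound 3 to compound 4 is methoxy in place of phenyl on an aromatic carbon, para to a large group.

Two kinds of measured step bear on this. The step of a 1.5-fold higher number from compound 1 to compound 3 (0.18 log units; within the scatter) shows that exchanging methyl for phenyl on that aromatic carbon left the number within the scatter, so groups of quite different size have been tolerated there. The steps of a 7.5-fold higher number from compound 1 to compound 2 (0.88 log units; beyond the scatter) and a 5.0-fold lower number from compound 2 to compound 3 (0.70 log units; beyond the scatter) show that the only modest shift seen came with the difluoro pattern, which compound 4 does not carry. Because of a 1.5-fold higher number from compound 1 to compound 3 (0.18 log units; within the scatter) the expected step of no change at the digits printed from compound 3 to compound 4 (within the scatter) is none beyond the scatter. Compound 4 is therefore estimated at 300 nM, with a range from 100 nM to 900 nM.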

Compound 4, half-maximal inhibitory concentration: 800 nM
The estimate for compound 4 lay 2.7-fold (0.43 log units) below the measured number, within the range that was stated.
By their numbers in this assay, from the lowest: compounds 1 and 3 (each within the scatter of the next); then compounds 4 and 2 (each within the scatter of the next).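

In this assay the exchange of phenyl for methoxy on this aromatic carbon gives a 2.7-fold higher number from compound 3 to compound 4 (0.43 log units; beyond the scatter) and the exchange of methyl for methoxy gives a 4.0-fold higher number from compound 1 to compound 4 (0.60 log units; beyond the scatter) so this position, which had seemed to accept very different groups, does respond to what sits on it. Size alone does not sort these compounds: methyl and phenyl lie within the scatter of each other although they differ greatly in size, while methoxy, the one group here that brings an oxygen and a hydrogen-bond acceptor, stands apart from both. The difluoro pattern also no longer stands alone, as the comparison gives a 1.9-fold lower number from compound 2 to compound 4 (0.27 log units; within the scatter) and this leaves those two compounds indistinguishable, so a weaker number at this position is not tied to the fluorines.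

Nothing measured here gives a reason for the shift seen with methoxy. From the compounds shown here alone, it remains open whether the oxygen is what matters, which an ethoxy group, a hydroxyl or an amine on the same carbon could help to show by falling with methoxy or with methyl and phenyl.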